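This account rests on a few compounds, and the source may have more. Where it says the series, first, only, none or still open, it means among the compounds named here.

Measured compounds:
Compound 1 `CN1C(=S)[C@@H](NC(=O)c2nc(Cc3ccccc3)n(C)n2)COc2ccccc21`. In a toxicity assay on HT-29 cells (Homo sapiens) for cytotoxicity (a lower number here means that less compound is tolerated, a higher number that more compound is tolerated), compound 1 gives > 100000 nM, which is a limit of the assay.
Compound 2 `CCn1nc(C(=O)N[C@H]2COc3ccccc3N(C)C2=S)nc1Cc1ccccc1`. In this assay compound 2 gives > 100000 nM, also a limit.
Compound 3 `CC(C)n1nc(C(=O)N[C@H]2COc3ccccc3N(C)C2=S)nc1Cc1ccccc1`. In this assay compound 3 gives > 100000 nM, again a limit.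

Compound 3 thus stands at the limit of > 100000 nM in this assay, at which 3 of the 3 values shown sit, and no numbered value separates it from compound 1 or compound 2. Compound 4 `CN1C(=S)[C@@H](NC(=O)c2nc(Cc3ccccc3)n(C3COC3)n2)COc2ccccc21` differs from compound 3 by oxetan-3-yl in place of isopropyl on an aromatic nitrogen. The measured steps that bear on this change all alter the group on the same aromatic nitrogen: a step that the two limits leave unreadable from compound 1 to compound 2, a step that the two limits leave unreadable from compound 1 to compound 3 and a step that the two limits leave unreadable from compound 2 to compound 3. All three run between limits, their sizes cannot be read, and they give no direction. No step beyond the scatter is therefore expected in this assay. Compound 4 is expected to give about 150000 nM, between 50000 nM and 500000 nM. This corresponds to an expected step that the limit leaves unreadable from compound 3 to compound 4.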

Compound 4, half-maximal cytotoxic concentration: > 100000 nM
Compound 4: no number, only a limit; the forecaster's own chance of this, stated with the estimate: 85%; the middle value lies beyond the limit too.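

In this assay compound 4 gives > 100000 nM, again a limit, so its steps from compound 1, compound 2 and compound 3 cannot be read. The compounds shown leave open whether changing the group on the aromatic nitrogen alters cytotoxicity at all: the limit of > 100000 nM in this assay, at which 4 of the 4 values shown sit.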